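This account rests on a few compounds, and the source may have more. Where it says the series, first, only, none or still open, it means among the compounds named here.

Three esters sharing the same core have been measured in a physicochemical assay for metabolic stability, in phosphate buffer, at pH 7.4; a lower number here means that the compound disappears faster, a higher number that the compound lasts longer. Compound 1 `Cc1nc(C)c(C(=O)Oc2ccc(-c3cc(=O)c4c(O)c(O)c(O)cc4o3)cc2)nc1C` gives 15.1 h, and compound 2 `Cc1nc(C)c(COC(=O)COc2ccc(-c3cc(=O)c4c(O)c(O)c(O)cc4o3)cc2)nc1C` gives 21.4 h, two values within the usual scatter of each other. Compound 3 `Cc1nc(C)c(C(=O)NCC(=O)Oc2ccc(-c3cc(=O)c4c(O)c(O)c(O)cc4o3)cc2)nc1C` stands apart in this assay at > 72 h, which is a limit of the assay and not a number.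

Compound 4 `Cc1nc(C)c(C(=O)N[C@@H](C(=O)Oc2ccc(-c3cc(=O)c4c(O)c(O)c(O)cc4o3)cc2)C(C)C)nc1C` differs from compound 3 by isopropyl in place of hydrogen on a saturated chain carbon bound to an amide-type nitrogen and a carbonyl carbon. Among the compounds with values here, no measured pair shows this change directly, so any forecast in this assay remains an expectation. It rests on compound 3, whose reading of > 72 h is a limit. The step that the limit leaves unreadable from compound 3 to compound 4 is expected to be small, with no drop beyond the scatter, and the assay may again return only a limit. For compound 4 the estimated half-life is 100 h, with an expected range from 55 h to 180 h.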

Compound 4, half-life: > 72 h
Compound 4 was reported as a limit; the forecaster's own chance of this, stated with the estimate: 70%; the middle value lies beyond the limit too.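

In this assay, within the data shown here, compound 3 and compound 4 both return a limit and not a number, so no step between them can be read: the limit of > 72 h in this assay, at which 2 of the 4 values shown sit. The compounds shown leave open how long either compound lasts, and whether isopropyl in place of hydrogen changes the half-life at all.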